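Ester to acid on the sulfonamide series

The source may hold more compounds than are shown below. What is called first, only, known or untested is meant among the compounds shown, and "the series" means these compounds.

Measured compounds:
Compound 1, `COc1cc(OC)c(/C=C/S(=O)(=O)Nc2ccc(OC)c(O)c2)c(OC)c1`: 15 nM
Compound 2, `COc1cc(OC)c(/C=C/S(=O)(=O)Nc2ccc(OC)c(N)c2)c(OC)c1`: 3 nM
Compound 3, `COC(=O)C(C)(C)Nc1cc(NS(=O)(=O)/C=C/c2c(OC)cc(OC)cc2OC)ccc1OC`: 300 nM

In a functional assay on K562 cells (Homo sapiens) for cytotoxicity, read by trypan blue exclusion, with a stated time of 96 h (on this read-out higher numbers stand for weaker inhibition and lower numbers for stronger inhibition), compound 3 gives 300 nM, the highest of the three numbers. Its nearest neighbour is compound 1, reached by a 20-fold higher number from compound 1 to compound 3 (1.30 log units; beyond the scatter); the gap to compound 2 is wider, a 100-fold higher number from compound 2 to compound 3 (2.00 log units; beyond the scatter), and both steps lie beyond the scatter. Within this set, compound 3 therefore stands as the weakest inhibitor.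

Compound 4, `COc1cc(OC)c(/C=C/S(=O)(=O)Nc2ccc(OC)c(NC(C)(C)C(=O)O)c2)c(OC)c1`, differs from compound 3 in one place: hydrogen in place of methyl on an oxygen next to a carbonyl group.

Among the measured compounds shown here, none of the measured steps covers this change. The steps that do exist concern the hydroxy, the amino and the 1-(methoxycarbonyl)-1-methylethyl substituent on the aromatic ring, not the methyl on the oxygen next to the carbonyl group. What they show is that the large substituent on the ring nitrogen carried compound 3 far above compounds 1 and 2; the carboxy variant keeps that substituent, so no return to the low numbers of compound 1 or compound 2 is expected. For compound 4 in this assay a step of a 2.0-fold higher number from compound 3 to compound 4 (0.30 log units; within the scatter) is expected, modest and toward a higher number, with wide uncertainty. The estimate for compound 4 is 600 nM, between 150 nM and 3000 nM.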

Compound 4, half-maximal inhibitory concentration: 5 nM
Estimate against measurement, compound 4: 120-fold (2.08 log units) above; measured number below the stated range.
By their numbers in this assay, from the lowest: compounds 2 and 4 (each within the scatter of the next); then compound 1; then compound 3.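

In this assay, hydrogen in place of methyl on an oxygen next to a carbonyl group gives a 60-fold lower number from compound 3 to compound 4 (1.78 log units; beyond the scatter), so the high number of compound 3 goes with the methyl ester and not with the substituent on the nitrogen as a whole. With the carboxy end in place, the 1-carboxy-1-methylethyl group on the nitrogen gives a 1.7-fold higher number from compound 2 to compound 4 (0.22 log units; within the scatter) and the (1-carboxy-1-methylethyl)amino group in place of hydroxy gives a 3.0-fold lower number from compound 1 to compound 4 (0.48 log units; beyond the scatter), which shows that this position can carry a large substituent with no loss against either smaller compound. Nothing available bears on what lies behind the gap between ester and acid.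

From the compounds shown here alone, whether a primary amide or a hydroxymethyl group in place of the carboxy end would keep the low number remains open. So does whether an unbranched carboxymethyl chain on the same nitrogen would do so.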